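Working notes: aryl swap on the amine nitrogen of compound 2

The source may hold more compounds than are shown below. What is called first, only, known or untested is meant among the compounds shown, and "the series" means these compounds.

Measured so far in a functional assay on HEK293 cells for agonist activity at Glucose-dependent insulinotropic receptor (Homo sapiens), read by cAMP accumulation, with a stated time of 30 min; a higher number here means that more compound is needed for the effect, a lower number that less compound is needed:
compound 1 `COc1c(Nc2ccc(S(C)(=O)=O)cc2F)ncnc1OC1C[C@@H]2COC[C@@H](C1)N2C(=O)OC1(C)CC1` gives 97 nM
compound 2 `CC1(OC(=O)N2C[C@H]3COC[C@@H](C2)[C@@H]3Oc2ncnc(Nc3ccc(C#N)cc3Cl)c2F)CC1` gives 10 nM
compound 3 `CC1(COC(=O)N2CC3COCC(C2)C3Oc2ncnc(Nc3ccc(C#N)cc3Cl)c2F)COC1` gives 188 nM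

Compound 2 stands lowest of the three numbers in this assay. Compound 1 is the nearest to it and compound 3 the furthest, and both gaps lie beyond the scatter. Neither compound 1 nor compound 3 differs from compound 2 in a single place, so their numbers say only that both sit clearly above compound 2; nothing in them isolates the part of the molecule that is changed next.

Compound 4 `CC1(OC(=O)N2C[C@H]3COC[C@@H](C2)[C@@H]3Oc2ncnc(Nc3ccccc3F)c2F)CC1` is not yet measured. Against compound 2 the change is 2-fluorophenyl in place of 2-chloro-4-cyanophenyl on a nitrogen on an aromatic ring; the carbamate, the bicyclic amine and the shared core are kept. Going by the values given here, no step between two measured compounds that differ in one place exists in this set, so the size of the change cannot be read off a neighbouring pair. What the set does show is that every departure from compound 2 so far has raised the number beyond the scatter. On that basis the number for compound 4 is expected to rise by a 15-fold higher number from compound 2 to compound 4 (1.18 log units; beyond the scatter), a step beyond the scatter rather than none. The estimate for compound 4 in this assay is 150 nM, within 40 nM to 600 nM.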

Compound 4, half-maximal effective concentration: 6 nM
Beside the measured number, compound 4's estimate is 25-fold (1.40 log units) above it; the whole stated range lies above it.
By their numbers in this assay, from the lowest: compounds 4 and 2 (each within the scatter of the next); then compounds 1 and 3 (each within the scatter of the next).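

Working notes, continued. On a nitrogen on an aromatic ring, 2-fluorophenyl in place of 2-chloro-4-cyanophenyl gives, in this assay, a 1.7-fold lower number from compound 2 to compound 4 (0.22 log units; within the scatter), so the two compounds cannot be told apart in this read-out. For this pair, with the carbamate and the shared core kept, the nitrile and the chlorine of the 2-chloro-4-cyanophenyl group are therefore not required for a value in this range, and the smaller 2-fluorophenyl group, with no hydrogen-bond acceptor, serves equally well. No measurement that bears on why the two aryl groups read alike is available.

The swap removes the chlorine and the nitrile and introduces the fluorine in a single step, so the compounds shown do not separate what each of these atoms or groups contributes, and they give no reading for an unsubstituted phenyl on the same nitrogen. From the compounds shown here alone, it also remains open how far this position tolerates other groups, such as a phenyl ring carrying a carboxylic acid or an amine, and whether the equivalence of the two aryl groups holds with a different carbamate.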